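Swapping piperidin-1-yl for 4-ethylpiperazin-1-yl in compound 1

The source may report more compounds than this note shows. Statements on the series, on what has been measured and on what is new or still open speak of the compounds shown alone.

Compound 1 `Cc1nc(Nc2ccc3sc(C(=O)Nc4c(C)cccc4Cl)cc3c2)cc(N2CCCCC2)n1` has no result in a functional assay on K562 cells (Homo sapiens) for cytotoxicity, read by MTT assay and WST assay, with a stated time of 72 h; on this read-out higher numbers stand for weaker inhibition and lower numbers for stronger inhibition: for compound 1 the entry is "not determined" (no result reported), so there is no single number to place it by. Compound 2 `CCN(CC)CCCOc1cc2ncnc(Nc3ccc4sc(C(=O)Nc5c(C)cccc5Cl)cc4c3)c2cc1OC`, built on a different core, gives in this assay a value of 3550 nM. Compound 3 `CCN1CCN(c2cc(Nc3ccc4sc(C(=O)Nc5c(C)cccc5Cl)cc4c3)nc(C)n2)CC1` carries 4-ethylpiperazin-1-yl in place of piperidin-1-yl on an aromatic carbon. Going by the values given here, no step between measured compounds covers this change, so the expected size of the step in this assay is none beyond the scatter, in no set direction. On that basis compound 3 is estimated at 2500 nM in this assay, within 300 nM to 20000 nM.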

Compound 3, half-maximal inhibitory concentration: 16900 nM
For compound 3 the middle estimate is 6.8-fold (0.83 log units) below the measured one; the measured number falls inside the stated range.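

No step can be read between compound 1 and compound 3 in this assay, where compound 3 gives 16900 nM. The compounds shown leave open what swapping piperidin-1-yl for 4-ethylpiperazin-1-yl does to this value. No supporting evidence bears on the result.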